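From 2-chlorophenyl to 3-hydroxyphenyl against HCT-116 cells

This account rests on a few compounds, and the source may have more. Where it says the series, first, only, none or still open, it means among the compounds named here.

Compound 1 `COc1ccc(OC)c(Nc2nc(/C=C/c3ccccc3OC(C)=O)nc3ccccc23)c1`: > 25000 nM
Compound 2 `COc1ccccc1/C=C/c1nc(Nc2ccccc2Cl)c2ccccc2n1`: 16100 nM

Among the compounds with values here, in a functional assay on HCT-116 cells (Homo sapiens) for antiproliferative activity, with a stated time of 72 h (on this read-out higher numbers stand for weaker inhibition and lower numbers for stronger inhibition), compound 2 gives 16100 nM, the only actual number so far. Compound 1 stands at > 25000 nM, which is a limit of the assay and not a number. Compound 3 `COc1ccccc1/C=C/c1nc(Nc2cccc(O)c2)c2ccccc2n1` carries 3-hydroxyphenyl in place of 2-chlorophenyl on a nitrogen on an aromatic ring. Within the data shown here, no measured pair shows such a change. With compound 2 at 16100 nM, inhibition is weak, so more room lies toward stronger inhibition. A moderate gain is therefore expected, with the estimated step of a 2.7-fold lower number from compound 2 to compound 3 (0.43 log units; beyond the scatter). For compound 3 the estimated value is 6000 nM, with an expected range from 800 nM to 25000 nM.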

Compound 3, half-maximal inhibitory concentration: 16400 nM
Estimate against measurement, compound 3: 2.7-fold (0.44 log units) below; measured number inside the range.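

In this assay, placing 3-hydroxyphenyl where 2-chlorophenyl stood on the nitrogen gives a 1.0-fold higher number from compound 2 to compound 3 (0.01 log units; within the scatter). This first readable step shows that a hydrogen-bond donor and acceptor can enter at this position with no gain in antiproliferative activity, and compound 2 and compound 3 cannot be told apart. Compound 1 remains at a limit of the assay, not a number: the limit of > 25000 nM in this assay, at which 1 of the 3 values shown sits.

Going by these compounds, whether an aminophenyl or a carboxyphenyl group on this nitrogen would shift the value stays open. The compounds shown also leave open whether a pyridyl ring there would do so.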